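Working notes: from compound 2 to compound 3

The source may hold more compounds than are shown below. What is called first, only, known or untested is meant among the compounds shown, and "the series" means these compounds.

Of the compounds shown here, two sharing one core have numbers so far in a functional assay on HeLa cells (Homo sapiens) for cytotoxicity, read by MTT assay, with a stated time of 24 h; a higher number here means a weaker inhibitor, a lower number a stronger inhibitor. In this assay, compound 1 (`COc1cc(/C=C2\CN(C)C/C(=C\c3ccc(F)cc3)C2=O)cc(OC)c1`) gives 10200 nM, and compound 2 (`COc1cc(/C=C2\CN(C)C/C(=C\c3ccc(Br)cc3)C2=O)cc(OC)c1`) gives 5900 nM. Compound 2 therefore stands level with compound 1 on these numbers, and the pair cannot be ranked.

Compound 3 (`COc1cc(/C=C2\CN(C)C/C(=C\c3ccc(Cl)cc3Cl)C2=O)cc(OC)c1`) is still unmeasured. Its structure has 2,4-dichlorophenyl in place of 4-bromophenyl on a double-bonded chain carbon bound to a double-bonded ring carbon. Among the measured compounds shown here, no measured compound carries a 2,4-dichlorophenyl group, and this change adds a second halogen to the phenyl ring. For the measured compounds named here, the only measured step that bears on it is bromo in place of fluoro on an aromatic carbon, a 1.7-fold lower number from compound 1 to compound 2 (0.24 log units; within the scatter). That single step is weak guidance, but it gives no ground to expect a shift beyond the scatter in this assay, and no direction is firmly expected.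

The estimated step, expected to stay within the scatter, is a 1.1-fold lower number from compound 2 to compound 3 (0.03 log units; within the scatter). For compound 3 the expected value is 5500 nM, with an estimated range of 2200 nM to 13000 nM.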

Compound 3, half-maximal inhibitory concentration: 7760 nM
Beside the measured number, compound 3's estimate is 1.4-fold (0.15 log units) below it, within the range that was stated.
By their numbers in this assay, from the lowest: compounds 2, 3 and 1 (each within the scatter of the next).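

With 2,4-dichlorophenyl on a double-bonded chain carbon bound to a double-bonded ring carbon, this assay shows a 1.3-fold higher number from compound 2 to compound 3 (0.12 log units; within the scatter) when it replaces 4-bromophenyl and a 1.3-fold lower number from compound 1 to compound 3 (0.12 log units; within the scatter) when it replaces 4-fluorophenyl, so neither step leaves the scatter. The earlier pair covered only one halogen exchanged for another, whereas this change brings a second halogen onto the phenyl ring, and the three compounds still cannot be ranked on these numbers in this assay for this series. No measurement at hand bears on what lies behind these small differences.

Going by these compounds, all three groups at this position are halogen-bearing phenyl rings, so it remains open whether the numbers would stay this close with an amine, a carboxylic acid or a longer chain on the phenyl ring in place of the halogens. The compounds shown also leave open whether any change at this position can move the number in this assay beyond the scatter at all.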